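Shortening both amine substituents of compound 3

The compounds below may be only part of what the source reports. "The series", "measured", "known", "first", "only" and "open" are said of these compounds alone.

Measured compounds in this study:
compound 1 `CCCN(Cc1c(C(F)(F)F)nc2n1CCCN2c1c(C)cc(C)cc1C)CC1CC1`: 32 nM
compound 2 `CCCN(CC1CC1)C(=O)c1c(CC)nc2n1CCC(=O)N2c1c(C)cc(C)cc1C`: > 5000 nM
compound 3 `CCCN(Cc1c(C(F)(F)F)nc2n1CCCN2c1c(C)cc(C)cc1C)CC1CCC1`: 21 nM

In an in vitro assay on IMR-32 cells for displacement of a labelled ligand from corticotropin-releasing factor receptor 1 (Homo sapiens) (on this read-out lower numbers stand for stronger inhibition and higher numbers for weaker inhibition), compound 3 gives 21 nM. Its nearest neighbour is compound 1, which gives 32 nM, and the two numbers sit within the usual scatter of each other. For compound 2 this assay reports only a limit, > 5000 nM.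

Compound 4 `CCN(Cc1c(C(F)(F)F)nc2n1CCCN2c1c(C)cc(C)cc1C)CC1CC1` differs from compound 3 by (cyclopropylmethyl)(ethyl)amino in place of (cyclobutylmethyl)(propyl)amino on a saturated chain carbon bound to an aromatic carbon. Among the measured compounds shown here, one measured step bears on part of this change: a 1.5-fold lower number from compound 1 to compound 3 (0.18 log units; within the scatter), which covers the ring part in the reverse direction and stayed within the scatter. The shortening from propyl to ethyl has no measured counterpart among these compounds. Compound 4 is therefore expected to show a step of a 2.1-fold higher number from compound 3 to compound 4 (0.33 log units; beyond the scatter) in this assay, with the wider uncertainty coming from the untested chain shortening. The estimate for compound 4 is 45 nM, with a range from 15 nM to 150 nM.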

Compound 4, inhibition constant: 31 nM
Compound 4: the middle estimate sits 1.5-fold (0.16 log units) above what was measured, and the stated range covers the measured number.
By their numbers in this assay, from the lowest: compounds 3, 4 and 1 (each within the scatter of the next). At a limit, above all of these: compound 2.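

Shortening propyl to ethyl, which no earlier pair covered, now has a measure of its own in this assay with a 1.0-fold lower number from compound 1 to compound 4 (0.01 log units; within the scatter) and the cyclopropylmethyl group left in place. The whole exchange of (cyclobutylmethyl)(propyl)amino for (cyclopropylmethyl)(ethyl)amino gives a 1.5-fold higher number from compound 3 to compound 4 (0.17 log units; within the scatter) and so, among these compounds, neither the chain change nor the full exchange on this saturated chain carbon leaves the scatter. Nothing in the data shown bears on why these numbers stay so close. The compounds shown leave open how far this tolerance extends, whether a butyl chain in place of propyl or a cyclopentyl ring in place of cyclobutyl would hold the number. They also leave open whether a hydroxyl group or a carboxylic acid on these amine substituents would be accepted.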